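Cytotoxicity notes: adding a second methoxy to compound 3

The source may report more compounds than this note shows. Statements on the series, on what has been measured and on what is new or still open speak of the compounds shown alone.

The series shares one core; compound 1 `CCOC(=O)CCCCCOc1cccc(CN(C(=O)c2ccc(-c3cccc(-c4ccccc4)c3)cc2)C(C)C)c1` carries a phenyl on an aromatic carbon of the shared core, compound 2 `CCOC(=O)CCCCCOc1cccc(CN(C(=O)c2ccc(-c3cccc(OC(C)C)c3)cc2)C(C)C)c1` an isopropoxy, and compound 3 `CCOC(=O)CCCCCOc1cccc(CN(C(=O)c2ccc(-c3cccc(OC)c3)cc2)C(C)C)c1` a methoxy in the same place. In an ADME assay on HEK293 cells (Homo sapiens) for cytotoxicity, read by CellTiter-Glo and resazurin assay, with a stated time of 72 h (a higher number here means that more compound is needed for the effect, a lower number that less compound is needed), compound 1 reaches only a limit of the assay, > 26000 nM. Compound 2 likewise gives only a limit in this assay, > 26000 nM. Compound 3 gives a limit in this assay too, > 21000 nM. All three values are limits rather than numbers: the limit of > 26000 nM in this assay, at which 2 of the 3 values shown sit, and (the limit of > 21000 nM in this assay, at which 1 of the 3 values shown sits). The measured steps therefore cannot be sized: a step that the two limits leave unreadable from compound 1 to compound 2, a step that the two limits leave unreadable from compound 1 to compound 3, a step that the two limits leave unreadable from compound 2 to compound 3. Compound 3 thus stands at a limit, with no number to place it against the other two.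

Compound 4 `CCOC(=O)CCCCCOc1cccc(CN(C(=O)c2ccc(-c3cc(OC)cc(OC)c3)cc2)C(C)C)c1` differs from compound 3 by methoxy in place of hydrogen on an aromatic carbon. Among the compounds with values here, none of the measured steps bears on this change with a readable size; none moved any compound away from a limit. The change is expected to leave compound 4 at a limit as well, so the step from compound 3 to compound 4 is estimated as a step that the limit leaves unreadable from compound 3 to compound 4. Compound 4 is therefore estimated at 30000 nM, within a range from 15000 nM to 100000 nM.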

Compound 4, half-maximal effective concentration: > 26000 nM
Compound 4 ended at the assay's limit (the forecaster's own chance of this, stated with the estimate: 85%); the middle value is on the limit's open side.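

In this assay compound 4 gives > 26000 nM, a limit of the assay. Within the data shown here, no step among compound 1, compound 2, compound 3 and compound 4 can be read, as all four values are limits. The compounds shown leave open whether any of these groups shifts the half-maximal effective concentration in this assay at all.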